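The source may report more compounds than this note shows. Statements on the series, on what has been measured and on what is new or still open speak of the compounds shown alone.

Four compounds carry the same kind of change on one core nitrogen. In an ADME assay for permeability, using PAMPA, with a stated time of 30 min, at pH 7.4 (a higher number here means that the compound crosses the layer faster, a lower number that the compound crosses the layer more slowly), compound 1, `COc1ccc(-c2c(-c3ccc(OC)cc3)n(Cc3ccccc3)c3ncn(CCCO)c(=N)c23)cc1`, gives > 1000 10^-6 cm/s, which is a limit of the assay rather than a number. Compound 2, `COc1ccc(-c2c(-c3ccc(OC)cc3)n(Cc3ccccc3)c3ncn([C@H]4CC[C@H](O)CC4)c(=N)c23)cc1`, has 4-hydroxycyclohexyl in place of 3-hydroxypropyl on an aromatic nitrogen and in this assay compound 2 gives 196 10^-6 cm/s. That change made an at least 5.1-fold lower number from compound 1 to compound 2 (0.70 log units; beyond the scatter); one end of this step rests on (the limit of > 1000 10^-6 cm/s in this assay, at which 1 of the 3 values shown sits).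

Compound 3, `Cc1c(C)n(Cc2ccccc2)c2ncn(CCCO)c(=N)c12`, is built on a different core, and the difference between the two cores is not broken down here. In this assay compound 3 gives 609 10^-6 cm/s. Compound 4, `Cc1c(C)n(Cc2ccccc2)c2ncn([C@H]3CC[C@H](O)CC3)c(=N)c12`, has 4-hydroxycyclohexyl in place of 3-hydroxypropyl on an aromatic nitrogen, the same change as before, made at a place described in the same words.

The step from compound 3 to compound 4 in this assay is expected to be a 5.1-fold lower number from compound 3 to compound 4 (0.71 log units; beyond the scatter). That expectation rests on the measured at least 5.1-fold lower number from compound 1 to compound 2 (0.70 log units; beyond the scatter). Compound 4 is therefore estimated to give 120 10^-6 cm/s in this assay. The likely range for compound 4 is expected to run from 50 10^-6 cm/s to 300 10^-6 cm/s.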

Compound 4, apparent permeability: < 1 10^-6 cm/s
Compound 4: no number, only a limit; the forecaster's own chance of this, stated with the estimate: 5%; at least 120-fold (2.07 log units) between middle value and limit.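

On the second core, this assay shows an at least 600-fold lower number from compound 3 to compound 4 (2.78 log units; beyond the scatter) when 4-hydroxycyclohexyl takes the place of 3-hydroxypropyl on the aromatic nitrogen. Compound 4 gives < 1 10^-6 cm/s, which is a limit of the assay and not a number. In these two pairs the direction of the change carries over from one core to the other, but the data do not show whether its size carries over too, because each step has a limit at one end: the same change on two cores in this assay, an at least 5.1-fold lower number (0.70 log units; beyond the scatter) from compound 1 to compound 2 and an at least 600-fold lower number (2.78 log units; beyond the scatter) from compound 3 to compound 4; the limit leaves it open whether they differ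

Two cores are also too few to say how the same change would behave on a third core. Going by these compounds, it remains open whether a longer chain such as 5-hydroxypentyl, or a cyclohexyl ring carrying an amine instead of the hydroxyl, would follow the same direction on the aromatic nitrogen of either core.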